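Cytotoxicity notes: aryl to benzyl on the shared core

The source may hold more compounds than are shown below. What is called first, only, known or untested is meant among the compounds shown, and "the series" means these compounds.

Compound 3 `Cc1ccccc1-c1nnc(-c2sc(-c3cccnc3)nc2C)o1` is one of three measured members of the series. In an ADME assay on HCT-116 cells (Homo sapiens) for cytotoxicity, read by MTT assay (on this read-out lower numbers stand for higher toxicity in this test and higher numbers for lower toxicity in this test), compound 3 gives > 100 ug/mL, which is a limit of the assay and not a number. Compound 1 `Cc1nc(-c2cccnc2)sc1-c1nnc(-c2ccncc2)o1` in this assay gives > 100 ug/mL, likewise a limit. Compound 2 `Cc1nc(-c2cccnc2)sc1-c1nnc(-c2ccc(Br)cc2)o1` in this assay gives > 100 ug/mL, again a limit. All three values sit at the same limit (the limit of > 100 ug/mL in this assay, at which 3 of the 3 values shown sit), so the steps a step that the two limits leave unreadable from compound 1 to compound 2, a step that the two limits leave unreadable from compound 1 to compound 3 and a step that the two limits leave unreadable from compound 2 to compound 3 cannot be read in size. Compound 3 therefore stands at the same limit as the other two, and nothing separates it from them on what is shown.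

Compound 4 `Cc1nc(-c2cccnc2)sc1-c1nnc(Cc2ccccc2)o1` is the unmeasured member. Its difference from compound 3: benzyl in place of 2-methylphenyl on an aromatic carbon. Among the compounds with values here, no measured step concerns a change of this kind, and the three steps that exist are all unreadable. No step beyond the scatter is expected. The step that the limit leaves unreadable from compound 3 to compound 4 is estimated to be small. Compound 4 is expected to give about 150 ug/mL in this assay, within 50 ug/mL to 450 ug/mL, most likely once more as a limit.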

Compound 4, half-maximal cytotoxic concentration: > 100 ug/mL
Compound 4 was reported as a limit; the forecaster's own chance of this, stated with the estimate: 75%; the middle value is on the limit's open side.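

In this assay compound 4 also stands at a limit of the assay (> 100 ug/mL). No step from compound 1, compound 2 or compound 3 to compound 4 can be read in size, since all four values sit at one limit: the limit of > 100 ug/mL in this assay, at which 4 of the 4 values shown sit.

The compounds shown leave open what half-maximal cytotoxic concentration any of the four actually has, and whether benzyl and 2-methylphenyl differ at all.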